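Swapping an Amide Partner in a Vitamin D Receptor Series

A few compounds are considered here, and "the series" means these few. Any claim that something is new, unique, unknown or untested is made for them only; others in the source may bear on it.

In an assay on isolated protein for inhibition of vitamin D3 receptor (Homo sapiens), read by fluorescence polarization (a lower number here means a stronger inhibitor, a higher number a weaker inhibitor), compound 1 `CS(=O)(=O)c1ccc(C(=O)N2CCC(C(=O)N3CCc4ccccc4C3)CC2)cc1[N+](=O)[O-]` gives > 60000 nM, which is a limit of the measurement rather than a number. Compound 2 `CN(Cc1cccc(F)c1)C(=O)CN(C)C(=O)c1ccc(S(C)(=O)=O)c([N+](=O)[O-])c1` also reaches only a limit, > 60000 nM. Compound 3 `CN(Cc1ccccc1F)C(=O)CNC(=O)c1ccc(S(C)(=O)=O)c([N+](=O)[O-])c1` likewise returns a limit, > 60000 nM. So compound 1 stands exactly where every measured compound stands: at the limit of > 60000 nM in this assay, at which 3 of the 3 values shown sit. Within the data shown here, no compound here has a true number, and no measured pair differs in a single place, so no step can be read from the data.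

Compound 4 `CN(Cc1ccccc1F)C(=O)C1CCN(C(=O)c2ccc(S(C)(=O)=O)c([N+](=O)[O-])c2)CC1` has not yet been measured. It differs from compound 1 by (2-fluorobenzyl)(methyl)amino in place of 1,2,3,4-tetrahydroisoquinolin-2-yl on a carbonyl carbon. With every measured compound sitting at the limit, the expectation for compound 4 is that it remains there, and the estimated step that the limit leaves unreadable from compound 1 to compound 4 is expected to be none beyond the scatter. Compound 4 is therefore expected to give about 80000 nM in this assay, with an estimated range from 30000 nM to 200000 nM.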

Compound 4, half-maximal inhibitory concentration: > 60000 nM
Compound 4 gave a limit, no number; the forecaster's own chance of this, stated with the estimate: 85%; the middle value does not contradict the limit.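

Swapping the 1,2,3,4-tetrahydroisoquinolin-2-yl of compound 1 for the (2-fluorobenzyl)(methyl)amino of compound 4 gives no readable step, because both compounds return only a limit, not a number: the limit of > 60000 nM in this assay, at which 4 of the 4 values shown sit.

The compounds shown leave open which change to the shared core, if any, would give a true number.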